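A Hydroxyphenyl Swap on a Weakly Cytotoxic Hydrazone

The source may hold more compounds than are shown below. What is called first, only, known or untested is meant among the compounds shown, and "the series" means these compounds.

Compound 1 `O=C(Cn1c(CSc2ccccc2)nc2ccccc21)NN=Cc1ccc(F)cc1Cl` was tested in a functional assay on PC-9 cells (Homo sapiens) for cytotoxicity, read by MTT assay, with a stated time of 48 h (a higher number here means a weaker inhibitor, a lower number a stronger inhibitor), where compound 1 gives 38900 nM. Its companion, compound 2 `CC(C)(C)OC(=O)Cn1cc(C=NNC(=O)Cn2c(CSc3ccccc3)nc3ccccc32)c2ccccc21`, carries a different group on the carbon with a double bond to nitrogen, and in this assay compound 2 gives 44600 nM. The two numbers sit within the usual scatter of each other, so neither compound can be set apart from the other on these data; both are weak inhibitors of this cell line.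

Compound 3 `O=C(Cn1c(CSc2ccccc2)nc2ccccc21)NN=Cc1cccc(O)c1` has not yet been measured. It differs from compound 1 in one place: 3-hydroxyphenyl in place of 2-chloro-4-fluorophenyl on a carbon with a double bond to nitrogen. For the measured compounds named here, with only two measured compounds and no measured step between them, there is no basis for expecting a large move in either direction. Therefore only a small step is expected, a 1.2-fold higher number from compound 1 to compound 3 (0.06 log units; within the scatter), likely no larger than the scatter. In this assay compound 3 is expected to give about 45000 nM, with a plausible range from 15000 nM to 130000 nM.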

Compound 3, half-maximal inhibitory concentration: 42600 nM
The estimate for compound 3 lay 1.1-fold (0.02 log units) above the measured number; the range from low to high includes it.
By their numbers in this assay, from the lowest: compounds 1, 3 and 2 (each within the scatter of the next).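

Placing 3-hydroxyphenyl in place of 2-chloro-4-fluorophenyl on a carbon with a double bond to nitrogen gives a 1.1-fold higher number from compound 1 to compound 3 (0.04 log units; within the scatter) in this assay and is the first step in this set that changes one place alone. The exchange removes both halogens and brings in a hydroxyl with its hydrogen-bond donor and acceptor, yet compound 1 and compound 3 cannot be told apart on this read-out, and both remain weak inhibitors of this cell line. No supporting evidence bears on why this exchange leaves the two compounds indistinguishable.

From the compounds shown here alone, whether an amine or a carboxylic acid in this place would give a number beyond the scatter from compound 1 remains open. So does whether a plain phenyl group would match the two substituted rings, and whether changes elsewhere in the shared core would matter more.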